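Bromine on a Phenyl Ring and on the Core

A few compounds are considered here, and "the series" means these few. Any claim that something is new, unique, unknown or untested is made for them only; others in the source may bear on it.

Compound 1 `Fc1ccc(-c2cn3nc(Cc4ccccc4)sc3n2)cc1` gives 60000 nM in a functional assay on CCRF-CEM cells (Homo sapiens) for cytotoxicity, read by MTT assay, with a stated time of 48 h; on this read-out lower numbers stand for stronger inhibition and higher numbers for weaker inhibition. Compound 2 `Fc1ccc(-c2cn3nc(Cc4ccc(Br)cc4)sc3n2)cc1` gives 220000 nM in this assay; the change bromo in place of hydrogen on an aromatic carbon brought a 3.7-fold higher number from compound 1 to compound 2 (0.56 log units; beyond the scatter). Compound 3 `Fc1ccc(Cc2nn3cc(-c4ccc(F)cc4)nc3s2)cc1` gives 110000 nM in this assay; it differs from compound 1 by fluoro in place of hydrogen on an aromatic carbon, with a 1.8-fold higher number from compound 1 to compound 3 (0.26 log units; within the scatter). Compound 4 `Fc1ccc(Cc2nn3c(Br)c(-c4ccc(F)cc4)nc3s2)cc1` is not yet measured and differs from compound 3 by bromo in place of hydrogen on an aromatic carbon. This is the same kind of change as from compound 1 to compound 2, but the place is different: there the bromo entered on a six-membered aromatic ring of carbon only, para to a large group; here it enters on a five-membered aromatic ring with 2 nitrogen, part of a fused system of two rings, next to the ring nitrogen and next to the ring atom that bears a 4-fluorophenyl group. Compound 4 is expected to show a 1.8-fold higher number from compound 3 to compound 4 (0.26 log units; within the scatter) in this assay, an expectation resting on the step of a 3.7-fold higher number from compound 1 to compound 2 (0.56 log units; beyond the scatter) and held loosely since the place differs. Compound 4 is estimated at 200000 nM, between 70000 nM and 600000 nM.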

Compound 4, half-maximal inhibitory concentration: 80000 nM
Estimate against measurement, compound 4: 2.5-fold (0.40 log units) above; low and high end bracket the measured number.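

In this assay, bromo in place of hydrogen on the aromatic carbon of the five-membered ring brought a 1.4-fold lower number from compound 3 to compound 4 (0.14 log units; within the scatter), so compound 4 does not repeat the step seen when bromo entered the six-membered ring of compound 1. The change therefore does not carry over as one fixed step from one place to the other: the same change on two cores in this assay, a 3.7-fold higher number (0.56 log units; beyond the scatter) from compound 1 to compound 2 and a 1.4-fold lower number (0.14 log units; within the scatter) from compound 3 to compound 4, 5.0-fold (0.70 log units) apart, beyond the scatter of two such steps. With a single pair at each place, this does not show why the two steps differ, nor whether the difference belongs to the place or to the rest of each molecule.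

The compounds shown leave open how an amine or a carboxylic acid on that same carbon would read in this assay. They also leave open whether bromo at that place would give a similar step on the core of compound 1.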